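The source may hold more compounds than are shown below. What is called first, only, known or untested is meant among the compounds shown, and "the series" means these compounds.

Working notes on the series. In a physicochemical assay for solubility, read by HPLC, in phosphate buffer, with a stated time of 24 h, at 37 degrees C, at pH 7.4 (on this read-out higher numbers stand for higher solubility and lower numbers for lower solubility), compound 1 `Nc1cc(OCCNc2ccnc3cc(Cl)ccc23)nc(N)n1` reads 230 nM and compound 2 `CC(COc1cc(N)nc(N)n1)Nc1ccnc2cc(Cl)ccc12` reads 250 nM so the two stand within the scatter of each other, with no order between them. Compound 3 `CCC(COc1cc(N)nc(N)n1)Nc1ccnc2cc(Cl)ccc12` is still unmeasured and departs from compound 2 by a single change (methyl in place of hydrogen on a saturated chain carbon, two bonds along the chain from a nitrogen on an aromatic ring), which reads as methyl to ethyl. Among the compounds with values here, one measured step bears on this, also methyl in place of hydrogen on a saturated chain carbon but at another place in the chain: a 1.1-fold higher number from compound 1 to compound 2 (0.04 log units; within the scatter) and that step lies within the scatter. Within the data shown here, with this one step as the only guide, no step beyond the scatter is expected in this assay in either direction. The estimated step is small (a 1.0-fold lower number from compound 2 to compound 3 (0.02 log units; within the scatter)). Compound 3 is expected at 240 nM with an estimated range from 120 nM to 480 nM as its span.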

Compound 3, solubility: 20 nM
Compound 3: the middle estimate sits 12-fold (1.08 log units) above what was measured; measured number below the stated range.
By their numbers in this assay, from the lowest: compound 3; then compounds 1 and 2 (each within the scatter of the next).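

In this assay the change from methyl to ethyl gives a 13-fold lower number from compound 2 to compound 3 (1.10 log units; beyond the scatter) and, taken from the unsubstituted chain, ethyl in place of hydrogen gives a 12-fold lower number from compound 1 to compound 3 (1.06 log units; beyond the scatter) on the same saturated chain carbon. One added methyl, two bonds along the chain from a nitrogen on an aromatic ring, therefore moves this read-out well beyond the scatter, although the earlier methyl for hydrogen change, a 1.1-fold higher number from compound 1 to compound 2 (0.04 log units; within the scatter) and closer to that nitrogen, did not, so the outcome of this change depends on where it is made. Nothing available here speaks to the origin of the drop.

As far as these compounds go, whether a longer chain at this place lowers the number further or leaves it where compound 3 stands remains open. So does whether a hydroxyl or an amine on the ethyl group restores the number seen for compound 2.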